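This account rests on a few compounds, and the source may have more. Where it says the series, first, only, none or still open, it means among the compounds named here.

Of the compounds shown here, three built on one shared core have been measured in a functional assay on SR cells (Homo sapiens) for inhibition, read by sulforhodamine B assay, with a stated time of 48 h; a higher number here means a weaker inhibitor of growth, a lower number a stronger inhibitor of growth. Compound 1 `Nc1cc(N)c2nc(-c3ccccc3)c(Oc3ccc(Cl)c(Cl)c3)nc2c1` gives 33900 nM, the highest of the three numbers, which makes it the weakest inhibitor of growth in this set. Compound 3 `CCOC(=O)[C@H](CCC(=O)O)NC(=O)c1ccc(Sc2nc3cc(N)cc(N)c3nc2-c2ccccc2)cc1` gives 7760 nM, and compound 2 `Nc1cc(N)c2nc(-c3ccccc3)c(NCc3ccc(Cl)c(Cl)c3)nc2c1` gives 1620 nM; the gap from compound 1 to each of them lies beyond the usual scatter, so compound 1 stands clearly apart.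

Compound 4 `Nc1cc(N)c2nc(-c3ccccc3)c(Sc3ccc(F)cc3)nc2c1` has not yet been measured in this assay. It differs from compound 1 in a single place: (4-fluorophenyl)sulfanyl in place of 3,4-dichlorophenoxy on an aromatic carbon. Among the compounds with values here, no measured pair shows exactly this exchange, so the expectation must rest on what the three numbers show. Compound 3 also joins an aromatic ring to the shared core through sulfur, and its value of 7760 nM sits well below the number for compound 1. Compound 4 is therefore expected to give a lower number than compound 1, with the step of a 3.8-fold lower number from compound 1 to compound 4 (0.58 log units; beyond the scatter) estimated to fall beyond the scatter. The value for compound 4 is estimated at 9000 nM, with a likely range from 2500 nM to 35000 nM.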

Compound 4, concentration for 50% growth inhibition: 35500 nM
Estimate against measurement, compound 4: 3.9-fold (0.60 log units) below, and the stated range ends below it.
By their numbers in this assay, from the lowest: compound 2; then compound 3; then compounds 1 and 4 (each within the scatter of the next).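

In this assay placing (4-fluorophenyl)sulfanyl where 3,4-dichlorophenoxy stood, on the aromatic carbon next to the ring nitrogen, gives a 1.0-fold higher number from compound 1 to compound 4 (0.02 log units; within the scatter) and so leaves the two compounds indistinguishable in this read-out. This exchange alters two things together, the atom linking the outer ring to the shared core and the halogens on that ring, yet this pair shows that the combined change, with oxygen giving way to sulfur and two chlorine atoms to one fluorine, does not move the number beyond the scatter. Nothing measured here offers an explanation for this result, and no cause can be assigned to it.

On these data alone, what stays open is whether neither part of the exchange matters at this position or whether the two parts offset each other, a question that (3,4-dichlorophenyl)sulfanyl or 4-fluorophenoxy on the same carbon would separate. Also open, as far as these compounds go, is how this position responds to a group of a different kind, such as a simple amine or a short alkyl chain bearing a carboxylic acid.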